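The compounds below may be only part of what the source reports. "The series", "measured", "known", "first", "only" and "open" are said of these compounds alone.

Among the measured compounds shown here, compound 2, with structure `COc1ccc(NC(=O)CCC(=O)OCCCCCCSc2ccc([N+](=O)[O-])c3nonc23)cc1OC`, is one of two compounds measured in a functional assay on 143B cells (Homo sapiens) for inhibition, read by MTT assay, with a stated time of 72 h (on this read-out lower numbers stand for stronger inhibition and higher numbers for weaker inhibition), where it gives 2770 nM. Compound 1, with structure `O=C(CCC(=O)OCCCCCCSc1ccc([N+](=O)[O-])c2nonc12)Nc1ccccc1F`, gives 3030 nM in this assay; the step of a 1.1-fold lower number from compound 1 to compound 2 (0.04 log units; within the scatter) means that the two numbers cannot be told apart. Compound 2 thus stands lowest of the two, but only by a margin that carries no meaning. Compound 3, with structure `O=C(CCC(=O)OCCCCCCSc1ccc([N+](=O)[O-])c2nonc12)NCCN1CCCC1`, differs from compound 2 in one place: 2-(pyrrolidin-1-yl)ethyl in place of 3,4-dimethoxyphenyl on an amide-type nitrogen. For the measured compounds named here, the only measured step, a 1.1-fold lower number from compound 1 to compound 2 (0.04 log units; within the scatter), swaps one aromatic group for another on the same amide-type nitrogen and left the number unchanged, so it bears only loosely on a change to a non-aromatic group. On that basis, the expected step of a 1.3-fold higher number from compound 2 to compound 3 (0.10 log units; within the scatter) is no more than the scatter, with the direction uncertain. Compound 3 is therefore estimated at 3500 nM in this assay, within a range of 1200 nM to 10000 nM.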

Compound 3, half-maximal inhibitory concentration: 5580 nM
For compound 3 the middle estimate is 1.6-fold (0.20 log units) below the measured one; the range from low to high includes it.
By their numbers in this assay, from the lowest: compounds 2, 1 and 3 (each within the scatter of the next).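

Among the compounds shown here, until this result, only aromatic groups had been compared on the amide-type nitrogen; compound 3 brings a non-aromatic ring and a further nitrogen to that place. In this assay, the readings are a 2.0-fold higher number from compound 2 to compound 3 (0.30 log units; within the scatter) and a 1.8-fold higher number from compound 1 to compound 3 (0.27 log units; within the scatter), so even this larger change of group type does not move the number beyond the scatter of repeated measurements. No measured finding is available to explain these numbers. Still open, on these data alone, is whether a morpholine ring, a carboxylic acid or a longer chain ending in the pyrrolidine ring on the same amide-type nitrogen would also stay within the scatter or move beyond it. Also open, as far as these compounds go, is what would happen if a methyl group replaced the amide hydrogen.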